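A few compounds are considered here, and "the series" means these few. Any claim that something is new, unique, unknown or untested is made for them only; others in the source may bear on it.

Working notes on the sulfonamide series in a functional assay on Capan-2 cells (Homo sapiens) for inhibition, read by MTT assay, with a stated time of 72 h; on this read-out higher numbers stand for weaker inhibition of growth and lower numbers for stronger inhibition of growth.

Of the compounds shown here, two carry numbers so far. Compound 1 `COc1ccc(CNCCCNS(=O)(=O)c2cc(C(F)(F)F)cc(C(F)(F)F)c2)cc1OC` gives 15000 nM in this assay. Compound 2 `O=S(=O)(NCCCNCC1COc2ccccc2O1)c1cc(C(F)(F)F)cc(C(F)(F)F)c1` gives 2500 nM in this assay. Among the compounds with values here, the one step between them, a 6.0-fold lower number from compound 1 to compound 2 (0.78 log units; beyond the scatter), is the only measured change at the saturated chain carbon bound to the amine nitrogen. Compound 2 therefore stands at the lowest of the two numbers, with compound 1 the nearest neighbour at the higher number.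

Compound 3 `O=S(=O)(NCCCNCc1ccc(C(F)(F)F)cc1)c1cc(C(F)(F)F)cc(C(F)(F)F)c1` is the next point. The change from compound 2 is 4-(trifluoromethyl)phenyl in place of 2,3-dihydro-1,4-benzodioxin-2-yl on a saturated chain carbon bound to an amine nitrogen, at the same place as the earlier step; the group that enters brings trifluoromethyl rather than the ring oxygens that leave. Within the data shown here, no measured pair covers this group, and the single step at this position, a 6.0-fold lower number from compound 1 to compound 2 (0.78 log units; beyond the scatter), was modest. In this assay a step not far beyond the scatter is expected, with direction uncertain and a drift toward a higher number more likely than not, as a 1.6-fold higher number from compound 2 to compound 3 (0.20 log units; within the scatter). Compound 3 is therefore expected to give 4000 nM, within 1200 nM to 13000 nM.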

Compound 3, concentration for 50% growth inhibition: 2000 nM
The estimate for compound 3 lay 2.0-fold (0.30 log units) above the measured number, within the range that was stated.
By their numbers in this assay, from the lowest: compounds 3 and 2 (each within the scatter of the next); then compound 1.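

In this assay the swap of 2,3-dihydro-1,4-benzodioxin-2-yl for 4-(trifluoromethyl)phenyl gives a 1.3-fold lower number from compound 2 to compound 3 (0.10 log units; within the scatter) and so compound 2 and compound 3 cannot be told apart, although the group that enters has 0 hydrogen-bond acceptors and no ring oxygens against 2 hydrogen-bond acceptors in the group that leaves. The second route away from 3,4-dimethoxyphenyl gives a 7.5-fold lower number from compound 1 to compound 3 (0.88 log units; beyond the scatter) and so, with the earlier step, two different groups on the saturated chain carbon bound to the amine nitrogen now separate from compound 1, which means that the gap is not tied to the benzodioxin ring alone. No measurement at hand accounts for these steps.

The compounds shown leave open whether compound 1 stands apart through its two methoxy groups or through something shared with other substituted phenyl rings, a question that plain phenyl at this place would address. They also leave open how the numbers respond to a carboxylic acid on that ring, or to a longer chain between the sulfonamide and the amine.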